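A dichlorophenyl variant of compound 1 and its expected dose

A few compounds are considered here, and "the series" means these few. Any claim that something is new, unique, unknown or untested is made for them only; others in the source may bear on it.

Compound 1 `O=C(CN1CCN(c2ccccc2)CC1)N(c1ccccc1)c1ccccc1` was measured in a toxicity assay on the whole organism (strain albino) for activation, with Mus musculus as the target, with stated times of 30 min and 240 min (a higher number here means that more compound is needed for the effect, a lower number that less compound is needed), where compound 1 gives 50 mg/kg. Of the two numbers available it stands highest, and its nearest neighbour is compound 3 `O=C(CN1CCN(c2cccc(Cl)c2)CC1)N(c1ccccc1)c1ccccc1`, which in this assay gives 48.4 mg/kg; the step between them is a 1.0-fold lower number from compound 1 to compound 3 (0.01 log units; within the scatter). Compound 2 `Cc1cccc(N2CCN(CC(=O)N(c3ccccc3)c3ccccc3)CC2)c1C` yields only a limit in this assay, > 40 mg/kg. Because of the limit of > 40 mg/kg in this assay, at which 1 of the 3 values shown sits, the steps a step that the limit leaves unreadable from compound 1 to compound 2 and a step that the limit leaves unreadable from compound 2 to compound 3 cannot be read in size.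

The compound not yet measured, compound 4 `O=C(CN1CCN(c2ccc(Cl)c(Cl)c2)CC1)N(c1ccccc1)c1ccccc1`, differs from compound 1 by 3,4-dichlorophenyl in place of phenyl on an amine nitrogen in a ring. Among the measured compounds shown here, the one measured step that bears on this change is a 1.0-fold lower number from compound 1 to compound 3 (0.01 log units; within the scatter), where a single chloro entering an aromatic carbon left the dose within the scatter. Two chlorines on the same ring are expected to behave in a similar way, so no step beyond the scatter is anticipated in this assay. Compound 4 is therefore estimated to give 45 mg/kg, with a range from 25 mg/kg to 90 mg/kg, which corresponds to an expected step of a 1.1-fold lower number from compound 1 to compound 4 (0.05 log units; within the scatter).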

Compound 4, dose for half-maximal effect: 45 mg/kg
Estimate against measurement, compound 4: no gap at the digits printed, within the range that was stated.
By their numbers in this assay, from the lowest: compounds 4, 3 and 1 (each within the scatter of the next).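

A second chloro on an aromatic carbon gives a 1.1-fold lower number from compound 3 to compound 4 (0.03 log units; within the scatter), so the step seen with one chloro is not changed beyond the scatter when another enters the same ring. Taken as a whole, 3,4-dichlorophenyl in place of phenyl on the amine nitrogen in the ring gives a 1.1-fold lower number from compound 1 to compound 4 (0.05 log units; within the scatter), which shows that in this assay this position tolerates two chlorines as well as one, with all three values within the scatter. Compound 2 remains a limit, and the steps that involve it cannot be read: the limit of > 40 mg/kg in this assay, at which 1 of the 4 values shown sits.

The compounds shown leave open whether a different group on this ring, such as a methoxy group, an amine or a carboxylic acid, would move the dose beyond the scatter. They also leave open what a change elsewhere in the core of compound 1 would do in this assay.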